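The source may hold more compounds than are shown below. What is called first, only, known or untested is meant among the compounds shown, and "the series" means these compounds.

Series notes. Compound 1 `O=C(NCc1ccc(CNS(=O)(=O)c2ccccc2)cc1)c1cccnc1` in an assay on MDA-MB-231 cells for binding affinity to C-X-C chemokine receptor type 4 (Homo sapiens), read by immunofluorescence and microscopy, with stated times of 10 min and 30 min (on this read-out higher numbers stand for an effect only at larger amounts of compound and lower numbers for an effect already at smaller amounts), gives 10 nM, level with compound 3 `Cc1ccc(S(=O)(=O)NCc2ccc(CNC(=O)c3ccncc3)cc2)cc1` at the digits shown, which gives 10 nM; the two stand together as the lowest of the three numbers, while compound 2 `Cc1ccc(S(=O)(=O)NCc2ccc(CNC(=O)c3cccc(Cl)c3)cc2)cc1` gives 100 nM, the highest. Going by the values given here, the only measured step that alters the group on the carbonyl carbon is a 10-fold lower number from compound 2 to compound 3 (1.00 log units; beyond the scatter); there a halogen-bearing phenyl ring gave way to a pyridyl ring and the number fell. Compound 4 `O=C(NCc1ccc(CNS(=O)(=O)c2ccccc2)cc1)c1ccccc1F` is the unmeasured neighbour of compound 1: 2-fluorophenyl in place of pyridin-3-yl on a carbonyl carbon. This runs the other way from the measured step, a pyridyl ring leaving and a halogen-bearing phenyl ring entering, so the step to compound 4 is expected to raise the number; the ring attachment and the halogen differ from the measured pair, so a smaller step than the measured one cannot be excluded. The step expected is a 10-fold higher number from compound 1 to compound 4 (1.00 log units; beyond the scatter). Compound 4 in this assay is estimated at 100 nM, with a range from 30 nM to 300 nM.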

Compound 4, effective concentration (reported as EC, without a stated level of effect): 1000 nM
Compound 4: middle estimate off by 10-fold (1.00 log units), on the low side; measured number outside the range, above it.
By their numbers in this assay, from the lowest: compounds 1 and 3 (each within the scatter of the next); then compound 2; then compound 4.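

In this assay replacing pyridin-3-yl with 2-fluorophenyl on the carbonyl carbon gives a 100-fold higher number from compound 1 to compound 4 (2.00 log units; beyond the scatter) and is larger in size than a 10-fold lower number from compound 2 to compound 3 (1.00 log units; beyond the scatter) on the other sulfonyl side. This position therefore responds strongly in the core of compound 1 as well, and in both single-change pairs the compound with the pyridyl ring has the lower number, with neither pair going against this. Nothing at hand gives a reason for the size of the new step.

The change removes the ring nitrogen and adds fluorine together, leaving open which of the two carries the step; a plain phenyl on the same carbonyl carbon would separate them. Also open, from the compounds shown here alone, are how pyridin-3-yl and pyridin-4-yl compare on a single core and how a saturated piperidine ring would behave here.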